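Two Anilines on One Sulfonamide Core in Lung Cancer Cells

The source may report more compounds than this note shows. Statements on the series, on what has been measured and on what is new or still open speak of the compounds shown alone.

Compound 1 `COc1cc2ncnc(Nc3cccc(F)c3)c2cc1OCCCCC(=O)Nc1ccc(S(N)(=O)=O)cc1`: in a functional assay on NCI-H1975 cells (Homo sapiens) for antiproliferative activity, read by MTT assay, with a stated time of 72 h (a lower number here means a stronger inhibitor, a higher number a weaker inhibitor), compound 1 gives > 40000 nM, which is a limit of the assay and not a number.
Compound 2 `COc1cc2ncnc(Nc3cccc(Cl)c3F)c2cc1OCCCCC(=O)Nc1ccc(S(N)(=O)=O)cc1`: compound 2 gives 6930 nM.
Compound 3 `NS(=O)(=O)c1ccc(NC(=S)Nc2ccc3ncnc(Nc4cccc(Cl)c4F)c3c2)cc1`: compound 3 gives 25100 nM.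

Compound 3 has the highest number of the two that were measured, and its gap to compound 2 lies beyond the scatter. The difference between the core of compound 3 and the core of compound 2 is not broken down here.

Between compound 2 and compound 1 the change is 3-fluorophenyl in place of 3-chloro-2-fluorophenyl on a nitrogen on an aromatic ring, and it gave an at least 5.7-fold higher number from compound 2 to compound 1 (0.76 log units; beyond the scatter). The same change leads from compound 3 to compound 4 `NS(=O)(=O)c1ccc(NC(=S)Nc2ccc3ncnc(Nc4cccc(F)c4)c3c2)cc1`, namely (3-fluorophenyl in place of 3-chloro-2-fluorophenyl on a nitrogen on an aromatic ring), at the same kind of place.

Compound 4 is expected to follow the earlier step, so a change of about a 4.8-fold higher number from compound 3 to compound 4 (0.68 log units; beyond the scatter) is estimated. Compound 3 already gives 25100 nM. One of the three values shown already sits at the limit of > 40000 nM in this assay, at which 1 of the 3 values shown sits. Compound 4 would therefore be expected to reach or pass that limit. The estimate for compound 4 is 120000 nM, between 40000 nM and 400000 nM.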

Compound 4, half-maximal inhibitory concentration: 9660 nM
The estimate for compound 4 lay 12-fold (1.09 log units) above the measured number, outside the stated range (below it).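

In this assay, 3-fluorophenyl in place of 3-chloro-2-fluorophenyl gave a 2.6-fold lower number from compound 3 to compound 4 (0.41 log units; beyond the scatter). Set beside the earlier step on the other core, the same change did not carry over in direction or in size: the same change on two cores in this assay, an at least 5.7-fold higher number (0.76 log units; beyond the scatter) from compound 2 to compound 1 and a 2.6-fold lower number (0.41 log units; beyond the scatter) from compound 3 to compound 4, at least 14-fold (1.17 log units) apart, beyond the scatter of two such steps This shows that in these two pairs the outcome of the change depended on the core it was made on, but two pairs give no rule for other cores and do not show which part of the cores matters, and one of the two steps rests on a value that is a limit of the assay and not a number: the limit of > 40000 nM in this assay, at which 1 of the 4 values shown sits.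

The compounds shown leave open how a plain 3-chlorophenyl on the same nitrogen would read on each of the two cores. They also leave open whether the opposite steps would persist with a carboxylic acid in place of the sulfonamide.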